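A few compounds are considered here, and "the series" means these few. Any claim that something is new, unique, unknown or untested is made for them only; others in the source may bear on it.

In a functional assay on spleen for antagonist activity at Alpha-1B adrenergic receptor (Rattus norvegicus) (on this read-out lower numbers stand for lower potency and higher numbers for higher potency (the scale is a negative logarithm)), compound 1 `COc1cccc(OC)c1OCCNCCOc1ccccc1OCc1ccccc1C` gives 7.67, the lowest of the three measured numbers; compound 3 `COc1ccccc1COc1ccccc1OCCNCCOc1c(OC)cccc1OC` gives 8.13 and compound 2 `COc1cccc(OC)c1OCCNCCOc1ccccc1OCc1ccc(C)cc1` gives 8.43. Compound 4 `COc1cccc(OC)c1OCCNCCOc1ccccc1OCc1ccc(OC(C)C)cc1` is not yet measured; it differs from compound 1 in that (4-isopropoxyphenyl in place of 2-methylphenyl on a saturated chain carbon bound to an oxygen on an aromatic ring). The closest measured step is a number 0.76 log units higher from compound 1 to compound 2 (beyond the scatter), where a 4-methylphenyl replaced the same 2-methylphenyl; a number 0.46 log units higher from compound 1 to compound 3 (beyond the scatter) also moved away from compound 1 in the same direction. Whether a 4-isopropoxyphenyl behaves as the 4-methylphenyl did cannot be read from these three compounds, so the step is expected upward but with wider uncertainty: a number 0.63 log units higher from compound 1 to compound 4 (beyond the scatter). Compound 4 is therefore estimated at 8.3, between 7.7 and 8.9.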

Compound 4, negative logarithm of the antagonist equilibrium constant: 8.62
Compound 4: middle estimate off by 0.32 log units, on the low side; the range from low to high includes it.
By their numbers in this assay, from the lowest: compound 1; then compounds 3, 2 and 4 (each within the scatter of the next, the first and the last beyond it).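

In this assay, the place on a saturated chain carbon bound to an oxygen on an aromatic ring also accepts a 4-isopropoxyphenyl, with the step from the 2-methylphenyl reading (a number 0.95 log units higher from compound 1 to compound 4 (beyond the scatter)) and the step from the 2-methoxyphenyl reading (a number 0.49 log units higher from compound 3 to compound 4 (beyond the scatter)). The remaining step reads (a number 0.19 log units higher from compound 2 to compound 4 (within the scatter)), so compound 2 and compound 4 cannot be ordered. No supporting evidence bears on this result.

Still open, going by these compounds, is whether a 4-aminophenyl or a 4-carboxyphenyl at this place would hold these numbers.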